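Phenyl for Methyl on a Trimethoxyphenyl Isoxazole Series

The source may report more compounds than this note shows. Statements on the series, on what has been measured and on what is new or still open speak of the compounds shown alone.

Measured compounds:
Compound 1, `COc1cc(-c2cc(COCc3cn(Cc4cc(-c5ccccc5)cnc4Cl)nn3)on2)cc(OC)c1OC`, 112000 nM
Compound 2, `COc1cc(-c2cc(COCc3cn(Cc4cc(C)cnc4Cl)nn3)on2)cc(OC)c1OC`, 256000 nM
Compound 3, `COc1cc(C2=NOC(COCc3cn(Cc4cc(C)cnc4Cl)nn3)C2)cc(OC)c1OC`, 37700 nM

All three were tested in a functional assay on A549 cells (Homo sapiens) for cytotoxicity, read by MTT assay, with a stated time of 48 h; a higher number here means a weaker inhibitor, a lower number a stronger inhibitor. Compound 2 gives 256000 nM. Where compound 2 carries a methyl, compound 1 carries a phenyl, and compound 1 gives 112000 nM. That single change is described as phenyl in place of methyl on an aromatic carbon and made a step of a 2.3-fold lower number from compound 2 to compound 1 (0.36 log units; beyond the scatter).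

Compound 3 has a different core from compound 2; the difference between the two cores is not broken down here. Compound 3 gives 37700 nM, the lowest number of the three.

Compound 4, `COc1cc(C2=NOC(COCc3cn(Cc4cc(-c5ccccc5)cnc4Cl)nn3)C2)cc(OC)c1OC`, has not yet been measured in this assay. It is built from compound 3 by the same change, (phenyl in place of methyl on an aromatic carbon), that turned compound 2 into compound 1. On the assumption that this change behaves on the core of compound 3 as it did on the core of compound 2, a step of about a 2.2-fold lower number from compound 3 to compound 4 (0.35 log units; beyond the scatter) is expected, because compound 1 and compound 2 showed a 2.3-fold lower number from compound 2 to compound 1 (0.36 log units; beyond the scatter). For compound 4 the expected value is therefore 17000 nM, likely between 7000 nM and 40000 nM.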

Compound 4, half-maximal inhibitory concentration: 8600 nM
Compound 4: the middle estimate sits 2.0-fold (0.30 log units) above what was measured; low and high end bracket the measured number.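

In this assay, putting phenyl in place of methyl on the core of compound 3 gave a 4.4-fold lower number from compound 3 to compound 4 (0.64 log units; beyond the scatter), so the number fell on this core as well as on the core of compound 2. Set side by side, the two steps point the same way, and their sizes cannot be told apart: the same change on two cores in this assay, a 2.3-fold lower number (0.36 log units; beyond the scatter) from compound 2 to compound 1 and a 4.4-fold lower number (0.64 log units; beyond the scatter) from compound 3 to compound 4, 1.9-fold (0.28 log units) apart, within the scatter of two such steps In this series, then, the change carried from one core to the other with no measurable difference in its effect, but two cores are a small sample, so this does not show that it would carry to a third core, and it gives no reason why phenyl lowers the number.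

The compounds shown leave open what other groups would do in the same place on the ring, such as an amine, a carboxylic acid or a longer chain. They also leave open whether the step would hold in any other test.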